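Fluoro for methoxy on the hydroxypiperidinyl quinoxaline sulfone

A few compounds are considered here, and "the series" means these few. Any claim that something is new, unique, unknown or untested is made for them only; others in the source may bear on it.

Working notes on four sulfones sharing one core. Compound 1 `COc1ccc(S(=O)(=O)c2nc3ccccc3nc2N2CCCC2)cc1` is measured in a functional assay on A549 cells (Homo sapiens) for cytotoxicity, read by MTT assay, with a stated time of 72 h; a higher number here means a weaker inhibitor, a lower number a stronger inhibitor; its value > 50000 nM is a limit of the assay (the limit of > 50000 nM in this assay, at which 1 of the 3 values shown sits), not a number. Compound 2 `O=S(=O)(c1ccc(F)cc1)c1nc2ccccc2nc1N1CCCC1` carries fluoro in place of methoxy on an aromatic carbon and in this assay gives 31100 nM, so an at least 1.6-fold lower number from compound 1 to compound 2 (0.20 log units; that floor lies within the scatter). Compound 3 `COc1ccc(S(=O)(=O)c2nc3ccccc3nc2N2CCC(O)CC2)cc1` differs from compound 1 by 4-hydroxypiperidin-1-yl in place of pyrrolidin-1-yl on an aromatic carbon. In this assay compound 3 gives 5110 nM, a step of an at least 9.7-fold lower number from compound 1 to compound 3 (0.99 log units; beyond the scatter). Compound 4 `O=S(=O)(c1ccc(F)cc1)c1nc2ccccc2nc1N1CCC(O)CC1` is not yet measured; it differs from compound 3 by fluoro in place of methoxy on an aromatic carbon, the same change as from compound 1 to compound 2, at the same place. Resting on the modest change seen from compound 1 to compound 2 an at least 1.6-fold lower number from compound 1 to compound 2 (0.20 log units; that floor lies within the scatter), the expected step is a 1.5-fold lower number from compound 3 to compound 4 (0.16 log units; within the scatter). Compound 4 is estimated at 3500 nM in this assay, between 1500 nM and 10000 nM.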

Compound 4, half-maximal inhibitory concentration: 20200 nM
Compound 4: the middle estimate sits 5.8-fold (0.76 log units) below what was measured, outside the stated range (above it).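

In this assay, fluoro in place of methoxy does not carry over from the pyrrolidin-1-yl compounds to the 4-hydroxypiperidin-1-yl compounds, where it gives a 4.0-fold higher number from compound 3 to compound 4 (0.60 log units; beyond the scatter), and the two steps differ: the same change on two cores in this assay, an at least 1.6-fold lower number (0.20 log units; that floor lies within the scatter) from compound 1 to compound 2 and a 4.0-fold higher number (0.60 log units; beyond the scatter) from compound 3 to compound 4, at least 6.3-fold (0.80 log units) apart, beyond the scatter of two such steps. Read the other way, 4-hydroxypiperidin-1-yl in place of pyrrolidin-1-yl gives a 1.5-fold lower number from compound 2 to compound 4 (0.19 log units; within the scatter) among the fluoro compounds, and this too departs from its methoxy counterpart: the same change on two cores in this assay, an at least 9.7-fold lower number (0.99 log units; beyond the scatter) from compound 1 to compound 3 and a 1.5-fold lower number (0.19 log units; within the scatter) from compound 2 to compound 4, at least 6.3-fold (0.80 log units) apart, beyond the scatter of two such steps. Compound 1 gives > 50000 nM, a limit of the assay and not a number, so both gaps are floors, and this single set of four compounds shows that the two changes do not add, not why they fail to, nor how they behave elsewhere.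

Going by these compounds, whether a plain piperidin-1-yl or a morpholin-4-yl group would follow the pattern of the 4-hydroxypiperidin-1-yl or of the pyrrolidin-1-yl pair stays open. So does the behaviour of chloro or methyl in the place of fluoro.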